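The compounds below may be only part of what the source reports. "The series", "measured", "known", "first", "only" and "open" are said of these compounds alone.

Measured so far in a functional assay on CHO-K1 cells for antagonist activity at transient receptor potential cation channel subfamily V member 1 (Homo sapiens), read by FLIPR; on this read-out lower numbers stand for stronger inhibition and higher numbers for weaker inhibition:
compound 1 `CC(C(=O)NCc1ccc(C(F)(F)F)nc1N1CC=CCC1)c1ccc(NS(C)(=O)=O)c(F)c1` — 0.3 nM
compound 2 `C[C@H](C(=O)NCc1ccc(C(F)(F)F)nc1N1CCC(c2ccccc2)CC1)c1ccc(NS(C)(=O)=O)c(F)c1` — 0.3 nM

Compound 1 stands level with compound 2 at the digits shown; the two values lie within the scatter of each other, so no order between them can be read. Both carry the shared core, differing only in the group on the aromatic carbon that sits next to the ring nitrogen.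

Compound 3 `CC(C)OC1CCN(c2nc(C(F)(F)F)ccc2CNC(=O)C(C)c2ccc(NS(C)(=O)=O)c(F)c2)CC1` is not yet measured in this assay. Against compound 1 the change is a group of 10 heavy atoms (8 carbon, 1 nitrogen, 1 oxygen; one six-membered non-aromatic ring with 1 hetero atom) in place of a group of 6 heavy atoms (5 carbon, 1 nitrogen; one six-membered non-aromatic ring with 1 hetero atom), on an aromatic carbon. The enters group is 4-isopropoxypiperidin-1-yl.

Going by the values given here, no measured step covers this change. Compound 2 shows that a six-membered non-aromatic ring with 1 hetero atom bearing a substituent is tolerated at this place, since compound 2 gives 0.3 nM. The step of a 1.7-fold higher number from compound 1 to compound 3 (0.22 log units; within the scatter) is therefore expected to be small, probably none beyond the scatter, perhaps a slight weakening. Compound 3 is estimated at 0.5 nM, within 0.15 nM to 2 nM.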

Compound 3, inhibition constant: 3 nM
Beside the measured number, compound 3's estimate is 6.0-fold (0.78 log units) below it, and the stated range ends below it.
By their numbers in this assay, from the lowest: compounds 1 and 2 (each within the scatter of the next); then compound 3.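

At this aromatic carbon, next to the ring nitrogen, the change to 4-isopropoxypiperidin-1-yl in this assay gives a 10-fold higher number from compound 1 to compound 3 (1.00 log units; beyond the scatter) and is the only step in the series shown that can be read. It shows that this place does not treat every six-membered non-aromatic ring with 1 hetero atom alike, and that the enters group weakens inhibition, although compound 3 at 3 nM remains an active antagonist. Nothing available bears on what lies behind this step.

Still open, going by these compounds, is whether the loss follows the isopropoxy group or the saturated ring itself. Going by these compounds alone, a plain piperidin-1-yl, a 4-methoxypiperidin-1-yl or a 4-hydroxypiperidin-1-yl at this place could separate the two, and the single forms of compound 3 at its methyl-bearing carbon also remain to be compared.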